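A few compounds are considered here, and "the series" means these few. Any claim that something is new, unique, unknown or untested is made for them only; others in the source may bear on it.

Measured so far:
compound 1 `CCc1nc(N)c2nc(O)n(Cc3ccccc3)c2n1` gives 1 uM
compound 2 `CSc1nc2c(N)ncnc2n1Cc1ccccc1` gives > 10 uM

Among the compounds with values here, in a functional assay (spleen, spleen) for activation, with Mus musculus as the target (on this read-out higher numbers stand for an effect only at larger amounts of compound and lower numbers for an effect already at smaller amounts), compound 1 gives 1 uM, the only plain number among the two values shown. For compound 2 the read-out is a limit rather than a number, namely (the limit of > 10 uM in this assay, at which 1 of the 2 values shown sits). Within the data shown here, no step between measured compounds that differ in one place is available, so the two values say nothing more than that compound 1 is read as a number and compound 2 only as a limit.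

Compound 3 `CCCCSc1nc(N)c2nc(O)n(Cc3ccccc3)c2n1` has not been measured yet. It differs from compound 1 by butylsulfanyl in place of ethyl on an aromatic carbon. Without any measured step on this core, the expectation rests on compound 1 alone, and no direction of change beyond the scatter can be argued from the data. Compound 3 is therefore expected to give about 1 uM, within a range of 0.3 uM to 10 uM. The step of no change at the digits printed from compound 1 to compound 3 (within the scatter) is expected to stay within the usual scatter.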

Compound 3, minimum effective concentration: 0.01 uM
Compound 3: middle estimate off by 100-fold (2.00 log units), on the high side; measured number outside the range, below it.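

In this assay, within the data shown here, the change from ethyl to butylsulfanyl, on an aromatic carbon between two ring nitrogen atoms, gives a 100-fold lower number from compound 1 to compound 3 (2.00 log units; beyond the scatter) and so shows that this position, which no earlier pair could address, responds strongly to the group it carries. The change brings in a sulfur atom and a longer chain together, so the step belongs to the exchange as a whole and not to either feature alone. No measurement shown gives a reason for the size of this step.

The compounds shown leave open whether the sulfur or the chain length matters more, which a pentyl chain or a methylsulfanyl group at this place would help to separate. Also open, from the compounds shown here alone, is whether compound 3 with its 0.01 uM would be matched by a butylamino group at this place or by a carboxylic acid at the end of the chain.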